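A few compounds are considered here, and "the series" means these few. Any claim that something is new, unique, unknown or untested is made for them only; others in the source may bear on it.

Compound 1 `OC(c1ccc(Cl)cc1)(c1ccc(Br)cc1)c1cncnc1`: 58700 nM in an ADME assay on L6 cells (Rattus norvegicus) for cytotoxicity, read by resazurin assay, with a stated time of 72 h; on this read-out higher numbers stand for weaker inhibition and lower numbers for stronger inhibition
Compound 2 `OC(c1ccc(Cl)cc1)(c1cccnc1)c1ccccc1F`: > 100000 nM, a limit of the assay rather than a number
Compound 3 `OC(c1ccc(Cl)cc1)(c1ccc(Br)cc1)c1cccnc1`: 57000 nM
Compound 4 `OC(c1ccc(Br)cc1)(c1ccc(C(F)(F)F)cc1)c1cccnc1`: not yet measured

Of the two numbers reported in this assay, compound 3 carries the lower one, but its gap to compound 1, a 1.0-fold lower number from compound 1 to compound 3 (0.01 log units; within the scatter), lies within the scatter, so the two cannot be told apart. For compound 2 the assay gives only a limit, (the limit of > 100000 nM in this assay, at which 1 of the 3 values shown sits). The step of an at least 1.7-fold lower number from compound 2 to compound 3 (0.24 log units; that floor lies within the scatter) therefore has only a floor, and that floor also lies within the scatter.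

Compound 4 differs from compound 3 in one place: trifluoromethyl in place of chloro on an aromatic carbon. Neither of the measured steps touches this aromatic carbon; both concern the saturated chain carbon bound to two aromatic carbons and an oxygen, and both are small. For the measured compounds named here, nothing among the measured compounds tests a chloro against a trifluoromethyl. The expectation for compound 4 in this assay is therefore a step of about a 1.1-fold lower number from compound 3 to compound 4 (0.06 log units; within the scatter), that is, no change beyond the scatter. Compound 4 is estimated at 50000 nM, with a range from 20000 nM to 100000 nM.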

Compound 4, half-maximal inhibitory concentration: 54700 nM
Compound 4: the middle estimate sits 1.1-fold (0.04 log units) below what was measured; the measured number falls inside the stated range.
By their numbers in this assay, from the lowest: compounds 4, 3 and 1 (each within the scatter of the next). At a limit, above all of these: compound 2.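

In this assay, for the compounds shown here, exchanging chloro for trifluoromethyl on an aromatic carbon para to a large group gives a 1.0-fold lower number from compound 3 to compound 4 (0.02 log units; within the scatter), the first direct reading at this position. The earlier steps shown here concerned only the saturated chain carbon bound to two aromatic carbons and an oxygen, whereas this one shows that replacing a group of 1 heavy atom with one of 4 heavy atoms on the six-membered aromatic ring of carbon only leaves the number within the scatter for this pair. Nothing shown here gives a measured property that would explain this absence of a visible change.

As far as these compounds go, the pair covers only chloro and trifluoromethyl at this aromatic carbon, so it remains open whether an amine, a carboxylic acid or a longer chain there would move the number beyond the scatter. Compound 2 is still known only through a limit, so its exact place relative to the other compounds also remains open: the limit of > 100000 nM in this assay, at which 1 of the 4 values shown sits.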